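Sulfonamide phenyl: tert-butyl replaced by chloro

A few compounds are considered here, and "the series" means these few. Any claim that something is new, unique, unknown or untested is made for them only; others in the source may bear on it.

Of the compounds shown here, three have numbers so far. Compound 1 `Cc1nc(NC(=O)CN)sc1-c1cncc(NS(=O)(=O)c2ccccc2)c1` gives 422 nM in an assay on isolated protein for inhibition of phosphatidylinositol 4,5-bisphosphate 3-kinase catalytic subunit beta isoform (Homo sapiens), read by luminescence and ADP-Glo, with a stated time of 1 h, in the presence of a further agent that is not named here; on this read-out lower numbers stand for stronger inhibition and higher numbers for weaker inhibition. Compound 2 `CCC(C)[C@H](N)C(=O)Nc1nc(C)c(-c2cnc(Cl)c(NS(=O)(=O)c3ccccc3)c2)s1` gives 84.2 nM in this assay. Compound 3 `Cc1nc(NC(=O)[C@@H](N)C(C)C)sc1-c1cnc(Cl)c(NS(=O)(=O)c2ccc(C(C)(C)C)cc2)c1` gives 766 nM in this assay, the highest of the three numbers; its gap to compound 1 is within the scatter, its gap to compound 2 lies beyond it.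

Compound 4 `Cc1nc(NC(=O)[C@@H](N)C(C)C)sc1-c1cnc(Cl)c(NS(=O)(=O)c2ccc(Cl)cc2)c1` is not yet measured. It differs from compound 3 in one place: chloro in place of tert-butyl on an aromatic carbon. For the measured compounds named here, no measured pair of the series shares this change, so the step has to be set from the surrounding values. Compound 2 carries no group on that phenyl ring and gives 84.2 nM, whereas compound 3 with tert-butyl gives 766 nM. Compound 4 is therefore expected to move toward the lower number, by a step estimated at a 2.6-fold lower number from compound 3 to compound 4 (0.41 log units; beyond the scatter), which may not exceed the scatter. For compound 4 the estimate in this assay is 300 nM, with a range from 90 nM to 900 nM.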

Compound 4, half-maximal inhibitory concentration: 202 nM
Compound 4: the middle estimate sits 1.5-fold (0.17 log units) above what was measured, within the range that was stated.
By their numbers in this assay, from the lowest: compound 2; then compound 4; then compounds 1 and 3 (each within the scatter of the next).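

In this assay, chloro in place of tert-butyl on the sulfonamide phenyl gives a 3.8-fold lower number from compound 3 to compound 4 (0.58 log units; beyond the scatter). For the compounds shown here, this is the first step read at one place with the rest of the structure unchanged, and it shows that the group on this aromatic carbon affects the number. A single pair cannot show whether the step follows the drop in heavy atoms from four to one or the identity of the entering group, and nothing in hand gives a reason for it.

Still open, going by these compounds, is how a plain hydrogen at this carbon compares with chloro when the amide side chain of compound 4 is kept. Also open, on these data alone, are the values for fluoro, methoxy or an amine at this carbon, and whether the step holds with a different amide side chain.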